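Bromo in Place of Chloro, Made a Second Time

A few compounds are considered here, and "the series" means these few. Any claim that something is new, unique, unknown or untested is made for them only; others in the source may bear on it.

The study compares two pairs of compounds in a functional assay on the whole organism with Mus musculus as the target, in the writhing test; a lower number here means that less compound is needed, a higher number that more compound is needed for the effect. Compound 1 `CC(=O)N1CCC(Sc2c[nH]c3ccc(Cl)cc23)CC1` gives 2.9 mg/kg in this assay, and compound 2 `CC(=O)N1CCC(Sc2c[nH]c3ccc(Br)cc23)CC1` gives 2.9 mg/kg. The two differ in one place, (bromo in place of chloro on an aromatic carbon), and the step of no change at the digits printed from compound 1 to compound 2 (within the scatter) shows that this exchange left the read-out where it was. Compound 3 `Cc1[nH]c2ccc(Cl)cc2c1SC1CCNCC1` has a different core; how the core of compound 3 differs from the core of compound 1 is not broken down here. In this assay compound 3 gives 0.8 mg/kg, the lowest number of the three measured compounds, and its gap to compound 1 and to compound 2 lies beyond the scatter. Compound 4 `Cc1[nH]c2ccc(Br)cc2c1SC1CCNCC1` is not yet measured. It differs from compound 3 by bromo in place of chloro on an aromatic carbon, the same change seen between compound 1 and compound 2, at a place described in the same words. Because the step of no change at the digits printed from compound 1 to compound 2 (within the scatter) was flat, compound 4 is expected to stand close to compound 3, with the expected step being no change at the digits printed from compound 3 to compound 4 (within the scatter). The estimate for compound 4 in this assay is 0.8 mg/kg, between 0.4 mg/kg and 1.6 mg/kg.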

Compound 4, dose for half-maximal effect: 0.7 mg/kg
Compound 4: the middle estimate sits 1.1-fold (0.06 log units) above what was measured; low and high end bracket the measured number.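

In this assay, bromo in place of chloro on the core of compound 3 gives a 1.1-fold lower number from compound 3 to compound 4 (0.06 log units; within the scatter), so the exchange that changed nothing measurable on the core of compound 1 again leaves the read-out within the scatter. The two steps do not differ: the same change on two cores in this assay, no change at the digits printed (within the scatter) from compound 1 to compound 2 and a 1.1-fold lower number (0.06 log units; within the scatter) from compound 3 to compound 4, 1.1-fold (0.06 log units) apart, within the scatter of two such steps. This shows that, on these two cores and in this one assay, the exchange carries over as a flat step, but it does not show the same for any other core, nor that a step of real size would carry over in the same way.

How a fluoro, a methoxy or an amine on this aromatic carbon would stand remains open, since the compounds shown hold only chloro and bromo there. Also open, from the compounds shown here alone, is which of the differences between the core of compound 1 and the core of compound 3 goes with the gap between their values.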